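A few compounds are considered here, and "the series" means these few. Any claim that something is new, unique, unknown or untested is made for them only; others in the source may bear on it.

Compound 1 `COc1nc2ccccc2n1C(=O)NCCCCc1ccccc1` is a urea in which a four-carbon chain carries a phenyl group. In a physicochemical assay for metabolic stability, read by HPLC, at pH 4.5, tested at 10 uM (on this read-out lower numbers stand for a shorter-lived compound and higher numbers for a longer-lived compound), compound 1 reaches only a limit of the assay, > 2 h. Compound 2 `O=C(NCCCCc1ccccc1)n1nnc2ccccc21` shares that chain and urea but has a different core. In this assay compound 2 also reaches a limit, > 2 h. Among the measured compounds shown here, both values therefore sit at the limit of > 2 h in this assay, at which 2 of the 2 values shown sit, so no measured step is known. Compound 3 `O=C(NCCCCc1ccccc1)n1cnc2ccccc21` differs from compound 1 by hydrogen in place of methoxy on an aromatic carbon. Without any measured step to lean on, the change a step that the limit leaves unreadable from compound 1 to compound 3 is expected to stay within the usual scatter. Compound 3 is estimated at 2.5 h, between 0.8 h and 6 h.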

Compound 3, half-life: > 2 h
Compound 3: a limit, no number; the forecaster's own chance of this, stated with the estimate: 55%; the middle value lies beyond the limit too.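

No step from compound 1 to compound 3 can be read, because both values are limits, not numbers: the limit of > 2 h in this assay, at which 3 of the 3 values shown sit.

The compounds shown leave open how long each one actually lasts in this assay, and whether hydrogen in place of methoxy changes that half-life at all.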